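A few compounds are considered here, and "the series" means these few. Any claim that something is new, unique, unknown or untested is made for them only; others in the source may bear on it.

The study concerns an assay for inhibition of ectonucleoside triphosphate diphosphohydrolase 3 (Homo sapiens), read by malachite green, with a stated time of 10 min (a lower number here means a stronger inhibitor, a higher number a weaker inhibitor), and the three measured compounds all return only a limit of the assay. Compound 1, `FC(F)(F)c1nc2c(Br)cccc2c(Cl)c1Br`, is the reference point of the step followed here. In this assay compound 1 gives > 300000 nM, which is a limit and not a number. Compound 2, `Cc1cccc(-c2c(C(F)(F)F)nc3c(-c4cccc(C)c4)cccc3c2-c2cccc(C)c2)c1`, is likewise recorded only as a limit, at > 300000 nM in this assay. Compound 3, `COc1ccc(OC)c(-c2cccc3c(Cl)c(Br)c(C(F)(F)F)nc23)c1`, also reaches only a limit in this assay, > 300000 nM. Thus compound 1 stands nowhere within a spread of numbers: all that is known is the limit of > 300000 nM in this assay, at which 3 of the 3 values shown sit, and compound 1 cannot be placed above or below compound 2 or compound 3.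

The unmeasured compound is compound 4, `N#Cc1cccc(-c2cccc3c(Cl)c(Br)c(C(F)(F)F)nc23)c1`. It differs from compound 1 by 3-cyanophenyl in place of bromo on an aromatic carbon. Among the measured compounds shown here, no step between two measured compounds is available to gauge such a change, and what compound 1 and compound 3 show is that both sit at the limit whether a bromo or an aryl group occupies that carbon. Compound 4 is therefore expected to show no step beyond the scatter, with a number no higher from compound 1 to compound 4 (the limit leaves the size open) expected as essentially none, and compound 4 is estimated at 300000 nM, within a range from 100000 nM to 1000000 nM, most likely again only as a limit.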

Compound 4, half-maximal inhibitory concentration: > 300000 nM
Compound 4: no number, only a limit; the forecaster's own chance of this, stated with the estimate: 80%; the middle value sits exactly at the limit.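

In this assay compound 4 gives > 300000 nM, which is a limit and not a number. Among the compounds shown here, compound 1 is also recorded only as a limit, so no step from compound 1 to compound 4 can be read: the limit of > 300000 nM in this assay, at which 4 of the 4 values shown sit. The compounds shown leave open how they rank and what change to the shared core would give a readable number.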